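This account rests on a few compounds, and the source may have more. Where it says the series, first, only, none or still open, it means among the compounds named here.

Compound 2 `CO[C@H]1O[C@H](COc2ccc(-c3ccccc3)cc2)[C@@H](O)[C@H](O)[C@H]1Oc1cccc(C(C)C)c1` carries the highest of the three numbers measured in a functional assay on HeLa cells (Homo sapiens) for cytotoxicity, read by MTT assay, with a stated time of 48 h (a higher number here means that more compound is needed for the effect, a lower number that less compound is needed), where compound 2 gives 35000 nM, though that position means little: compound 3 `CO[C@H]1O[C@H](COc2ccc(-c3ccccc3)cc2)[C@@H](O)[C@H](O)[C@H]1Oc1ccccc1C(C)C` gives 29000 nM and compound 1 `CO[C@H]1O[C@H](COc2ccc(-c3ccccc3)cc2)[C@@H](O)[C@H](O)[C@H]1Oc1ccc(C(C)C)cc1` gives 19000 nM, and the three steps between them, a 1.8-fold higher number from compound 1 to compound 2 (0.27 log units; within the scatter), a 1.5-fold higher number from compound 1 to compound 3 (0.18 log units; within the scatter) and a 1.2-fold lower number from compound 2 to compound 3 (0.08 log units; within the scatter), all stay within the scatter. These three compounds differ only in which isopropylphenyl is attached through an oxygen on a saturated carbon, so they cannot be ranked against one another.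

Compound 4 `CO[C@@H]1O[C@H](COc2ccc(-c3ccccc3)cc2)[C@@H](O)[C@H](O)[C@H]1Oc1cccc(C(C)C)c1` keeps the 3-isopropylphenyl of compound 2 and changes something else: the two compounds have the same atoms and bonds and differ only in configuration as drawn: 1 of 5 stereo elements differ; a stereocentre at a saturated ring carbon is drawn S in compound 2 and R in compound 4. Among the measured compounds shown here, none of the measured steps touches a stereocentre, so nothing among them says how large a step this change brings or in which direction. For the measured compounds named here, the only anchor is the value of compound 2, and the step of no change at the digits printed from compound 2 to compound 4 (within the scatter) is therefore expected to stay within the scatter. On that basis compound 4 is estimated at 35000 nM, with a range from 15000 nM to 80000 nM.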

Compound 4, half-maximal effective concentration: 32000 nM
Compound 4: the middle estimate sits 1.1-fold (0.04 log units) above what was measured, and the stated range covers the measured number.
By their numbers in this assay, from the lowest: compounds 1, 3, 4 and 2 (each within the scatter of the next).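

Redrawing one stereocentre at a saturated ring carbon from S to R gives a 1.1-fold lower number from compound 2 to compound 4 (0.04 log units; within the scatter) in this assay, so the two compounds cannot be told apart here. The earlier compounds shown here varied only the isopropylphenyl group, whereas this pair shows that, with the 3-isopropylphenyl group in place, the drawn configuration at this carbon has no effect that can be read in this assay. The comparison speaks to that single stereocentre alone: the fact that compounds 2 and 4 differ only in the configuration as drawn.

On these data alone, the R configuration at this carbon appears only with the 3-isopropylphenyl group, so it remains open whether the result would hold for the 2-isopropylphenyl and 4-isopropylphenyl compounds. Also open, as far as these compounds go, is how either configuration would behave if an amine or a carboxylic acid replaced the isopropyl group.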